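Removing a methoxy from a trimethoxyphenyl pyrazoline

The source may hold more compounds than are shown below. What is called first, only, known or untested is meant among the compounds shown, and "the series" means these compounds.

In a functional assay on OVCAR cells (Homo sapiens) for cytotoxicity, read by sulforhodamine B assay, with a stated time of 48 h (a lower number here means a stronger inhibitor, a higher number a weaker inhibitor), compound 1 `CC(=O)N1N=C(c2cccc3ccccc23)CC1c1ccccc1` gives 7820 nM. Compound 2 `COc1ccc(C2CC(c3cccc4ccccc34)=NN2C(C)=O)cc1` gives 6710 nM. Compound 3 `COc1ccc(C2CC(c3ccc4ccccc4c3)=NN2CC=O)c(OC)c1OC` gives 580 nM, the lowest of the three numbers.

Among the measured compounds shown here, the one change between the two measured analogues, (hydrogen in place of methoxy on an aromatic carbon), gave a 1.2-fold higher number from compound 2 to compound 1 (0.07 log units; within the scatter). The difference between the cores of compound 2 and compound 3 is not broken down here; their values show compound 3 with the lower number.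

Compound 4 `COc1ccc(C2CC(c3ccc4ccccc4c3)=NN2CC=O)cc1OC` is made from compound 3 by hydrogen in place of methoxy on an aromatic carbon. For the measured compounds named here, this is the same kind of change as the one from compound 2 to compound 1, not the same: there the vacated carbon was para to a large group, here it is ortho to a large group, ortho to a methoxy group and meta to a methoxy group. The step is nevertheless expected to be small, a 1.3-fold higher number from compound 3 to compound 4 (0.11 log units; within the scatter), because a 1.2-fold higher number from compound 2 to compound 1 (0.07 log units; within the scatter) stayed within the scatter. Compound 4 is therefore estimated at 750 nM in this assay, expected between 350 nM and 1600 nM.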

Compound 4, half-maximal inhibitory concentration: 2450 nM
Compound 4: middle estimate off by 3.3-fold (0.51 log units), on the low side; measured number above the stated range.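

In this assay, hydrogen in place of methoxy gave a 4.2-fold higher number from compound 3 to compound 4 (0.63 log units; beyond the scatter). The size of this step did not carry over from one core to the other: the same change on two cores in this assay, a 1.2-fold higher number (0.07 log units; within the scatter) from compound 2 to compound 1 and a 4.2-fold higher number (0.63 log units; beyond the scatter) from compound 3 to compound 4, 3.6-fold (0.56 log units) apart, beyond the scatter of two such steps. This shows that a small step on one core is no safe guide to the same change on another in this series, but it does not show what sets the two cases apart, as the cores differ and the vacated carbon has different surroundings, and two pairs support no general rule.

The compounds shown leave open how a hydroxyl, a fluorine or an amine would compare with methoxy at this carbon. They also leave open whether removing either remaining methoxy from compound 4 would give a step of similar size.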